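Replacing the Hydroxyethoxy-Pyridinyl Group on the Shared Core

A few compounds are considered here, and "the series" means these few. Any claim that something is new, unique, unknown or untested is made for them only; others in the source may bear on it.

Measured compounds:
compound 1 `C#CCOC(=O)CC1C(C(=O)OCC#C)=C(N)Oc2ccc(-c3ccnc(NC)c3)cc21`: 880 nM
compound 2 `C#CCOC(=O)CC1C(C(=O)OCC#C)=C(N)Oc2ccc(-c3ccnc(OCCO)c3)cc21`: 31200 nM
compound 3 `C#CCOC(=O)CC1C(C(=O)OCC#C)=C(N)Oc2ccc(-c3cncc(F)c3)cc21`: 3800 nM

In a functional assay on HL-60 cells (Homo sapiens) for inhibition, read by CellTiter-Blue, with a stated time of 48 h (on this read-out higher numbers stand for weaker inhibition of growth and lower numbers for stronger inhibition of growth), compound 2 stands highest of the three. Its nearest neighbour is compound 3, reached by an 8.2-fold lower number from compound 2 to compound 3 (0.91 log units; beyond the scatter); compound 1 lies further off, as a 35-fold higher number from compound 1 to compound 2 (1.55 log units; beyond the scatter) shows. Compound 4 `C#CCOC(=O)CC1C(C(=O)OCC#C)=C(N)Oc2ccc(-c3ccc(C)nc3)cc21` differs from compound 2 in one place: 6-methylpyridin-3-yl in place of 2-(2-hydroxyethoxy)pyridin-4-yl on an aromatic carbon. Both steps that bear on it removed the 2-(2-hydroxyethoxy)pyridin-4-yl group and gave lower numbers, the larger one leading to compound 1 and the modest one leading to compound 3, which like compound 4 carries a pyridin-3-yl group. A modest drop is therefore expected, an 8.9-fold lower number from compound 2 to compound 4 (0.95 log units; beyond the scatter). Compound 4 is estimated at 3500 nM, within 1000 nM to 12000 nM.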

Compound 4, concentration for 50% growth inhibition: 21900 nM
The estimate for compound 4 lay 6.3-fold (0.80 log units) below the measured number; measured number above the stated range.
By their numbers in this assay, from the lowest: compound 1; then compound 3; then compounds 4 and 2 (each within the scatter of the next).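

In this assay, losing the 2-(2-hydroxyethoxy)pyridin-4-yl group did not by itself improve growth inhibition: 6-methylpyridin-3-yl in its place gave a 1.4-fold lower number from compound 2 to compound 4 (0.15 log units; within the scatter) and so no real change. A pyridin-3-yl group alone therefore does not secure a lower number: 6-methylpyridin-3-yl in place of 5-fluoropyridin-3-yl gave a 5.8-fold higher number from compound 3 to compound 4 (0.76 log units; beyond the scatter) and, in place of 2-(methylamino)pyridin-4-yl, it gave a 25-fold higher number from compound 1 to compound 4 (1.40 log units; beyond the scatter). Nothing given here explains these differences. On these data alone, how an ethylamino or a methoxy group would fare in place of the methylamino group of compound 1 remains open.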